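The source may hold more compounds than are shown below. What is called first, only, known or untested is meant among the compounds shown, and "the series" means these compounds.

Notes on the series in an ADME assay on RAW264.7 cells (Mus musculus) for cytotoxicity, read by MTT assay, with a stated time of 24 h, in the presence of a further agent that is not named here; a higher number here means a weaker inhibitor, a lower number a stronger inhibitor. Compound 1 `COc1cc(OC)c2c(c1)C(C(O)c1ccc(O)cc1)OC2=O` carries the hydroxy group. In this assay compound 1 gives only a limit, > 40000 nM, so its position on the scale is not a number. Compound 2 `COCCOc1ccc(C(O)C2OC(=O)c3c(OC)cc(OC)cc32)cc1` has 2-methoxyethyl in place of hydrogen on an oxygen on an aromatic ring. In this assay compound 2 likewise reaches only a limit, > 40000 nM. Among the measured compounds shown here, the step that the two limits leave unreadable from compound 1 to compound 2 therefore cannot be read, and the only evidence bearing on substitution at this oxygen is the limit of > 40000 nM in this assay, at which 2 of the 2 values shown sit.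

Compound 3 `COc1cc(OC)c2c(c1)C(C(O)c1ccc(OCc3ccc(C)cc3)cc1)OC2=O` is the next member. Relative to compound 1 it shows (4-methylbenzyl in place of hydrogen on an oxygen on an aromatic ring). This is the same kind of change at the same oxygen as the step to compound 2. Neither measured compound gave a number in this assay, and no step beyond the scatter can be derived from them; the change itself offers no reason to expect compound 3 to fall under the limit. The step that the limit leaves unreadable from compound 1 to compound 3 is estimated to be essentially nil, with compound 3 expected most likely to return only a limit again. For compound 3 in this assay the expected value is 50000 nM, within 20000 nM to 200000 nM.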

Compound 3, half-maximal inhibitory concentration: > 40000 nM
Compound 3: no number, only a limit; the forecaster's own chance of this, stated with the estimate: 80%; the middle value does not contradict the limit.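

In this assay compound 3 gives only a limit, > 40000 nM. Among the compounds shown here, no new step can therefore be read among compound 1, compound 2 and compound 3. The compounds shown leave open where any of them lies on the scale, and whether substitution at this oxygen changes the read-out at all, with one observation so far: the limit of > 40000 nM in this assay, at which 3 of the 3 values shown sit.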